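Trifluoromethylbenzyl for cyanobenzyl, from a series at the limit

The source may hold more compounds than are shown below. What is called first, only, known or untested is meant among the compounds shown, and "the series" means these compounds.

In a functional assay on HepG2 cells (Homo sapiens) for antiproliferative activity, read by MTT assay, with a stated time of 24 h (a lower number here means a stronger inhibitor, a higher number a weaker inhibitor), compound 1 `COc1cccc(C(=O)Oc2ccc3c(=O)c(-c4cc(OC)c(OC)cc4OC)coc3c2)c1` gives > 10000 nM, which is a limit and not a number. Compound 2 `COc1cc(OC)c(-c2coc3cc(OCc4ccccc4C#N)ccc3c2=O)cc1OC` gives > 10000 nM, also a limit. Both compounds stand at the limit of > 10000 nM in this assay, at which 2 of the 2 values shown sit.

Compound 3 `COc1cc(OC)c(-c2coc3cc(OCc4cccc(C(F)(F)F)c4)ccc3c2=O)cc1OC` follows from compound 2 by one change, 2-cyanobenzyl to 3-(trifluoromethyl)benzyl: 3-(trifluoromethyl)phenyl in place of 2-cyanophenyl on a saturated chain carbon bound to an oxygen on an aromatic ring.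

Among the measured compounds shown here, the one measured step is a step that the two limits leave unreadable from compound 1 to compound 2, so it offers no size to carry over. The expected step in this assay is a step that the limit leaves unreadable from compound 2 to compound 3, and the data support no direction for it. The estimate for compound 3 is 12000 nM, with an expected range of 4000 nM to 30000 nM.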

Compound 3, half-maximal inhibitory concentration: 610 nM
Compound 3: the middle estimate sits 20-fold (1.29 log units) above what was measured; measured number outside the range, below it.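

Among the compounds shown here, at this oxygen on the aromatic ring, 3-(trifluoromethyl)benzyl gives an at least 16-fold lower number from compound 2 to compound 3 (1.21 log units; beyond the scatter) in this assay, the only value shown that is a number and not a limit. Against the (3-methoxyphenyl)carbonyl group, it gives an at least 16-fold lower number from compound 1 to compound 3 (1.21 log units; beyond the scatter), so the value depends on the group carried at this oxygen. The step between compound 1 and compound 2 cannot be read, as both sit at a limit: the limit of > 10000 nM in this assay, at which 2 of the 3 values shown sit.

Compound 2 and compound 3 differ in both the ring substituent and its numbered place, and the compounds shown do not separate the two. On these data alone, how a plain benzyl, or a longer chain ending in an amine, would read at this oxygen stays open.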